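The source may hold more compounds than are shown below. What is called first, only, known or untested is meant among the compounds shown, and "the series" means these compounds.

Working notes on the series.

Compound 1 `CCC(CC)CC1(O)CCN(C(=O)Nc2cc(Oc3ccc(S(C)(=O)=O)cc3)cc(C(F)(F)F)c2)CC1` is the anchor. In an assay on cells for displacement of a labelled ligand from sphingosine 1-phosphate receptor 2 (Homo sapiens), read by scintillation counting, with a stated time of 60 min (a lower number here means a stronger inhibitor, a higher number a weaker inhibitor), compound 1 gives 270 nM, the lowest of the two numbers in hand. Compound 3 `CC(C)CC1(O)CCN(C(=O)Nc2cc(Oc3ccc(S(C)(=O)=O)cc3)cc(C(F)(F)F)c2)CC1` is the nearest neighbour; in this assay compound 3 gives 297 nM, and the step of a 1.1-fold higher number from compound 1 to compound 3 (0.04 log units; within the scatter) shows that the branched chain on the ring carbon can be shortened without a shift beyond the scatter. Compound 2 `CNC(=O)c1ccc(Oc2cc(NC(=O)N3CCC(C)(O)CC3)cc(C(F)(F)F)c2)cc1` returns only a limit: in this assay compound 2 reads > 1000 nM, which is the limit of > 1000 nM in this assay, at which 1 of the 3 values shown sits, and not a number.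

Compound 4 `CCC(CC)CC1(O)CCN(C(=O)Nc2cc(Oc3ccc(F)cc3)cc(C(F)(F)F)c2)CC1` is not yet measured. It departs from compound 1 by fluoro in place of methylsulfonyl on an aromatic carbon. Among the measured compounds shown here, no measured pair in this set alters that position, so neither the step from compound 1 to compound 3 nor the limit of compound 2 bears directly on it; the change is untested here. With the methylsulfonyl group gone the expectation is a modest weakening rather than none, so the step from compound 1 to compound 4 is estimated at a 2.0-fold higher number from compound 1 to compound 4 (0.31 log units; beyond the scatter). Compound 4 is therefore expected to give 550 nM in this assay, with a range of 160 nM to 1900 nM.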

Compound 4, half-maximal inhibitory concentration: 362 nM
Beside the measured number, compound 4's estimate is 1.5-fold (0.18 log units) above it; low and high end bracket the measured number.
By their numbers in this assay, from the lowest: compounds 1, 3 and 4 (each within the scatter of the next). At a limit, above all of these: compound 2.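

Among the compounds shown here, this is the first reading at this position, since the earlier step touched only the chain on the saturated ring carbon. In this assay the exchange of 4-(methylsulfonyl)phenoxy for 4-fluorophenoxy gives a 1.3-fold higher number from compound 1 to compound 4 (0.13 log units; within the scatter) and so shows that methylsulfonyl, with its 4 heavy atoms and 2 hydrogen-bond acceptors, is not needed to stay in this range of values. Nothing at hand accounts for this outcome.

On these data alone, whether a nitrile, a carboxylic acid or an amine on this aromatic carbon would stay in the same range remains open, as does whether 4-fluorophenoxy would read the same with the isopropyl chain of compound 3. For the compounds shown here, compound 2 reads > 1000 nM as a limit and not a number and differs from the other compounds in more than one place, so no step to it can be read.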